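Swapping Methoxy for Bromo in Compound 3

This account rests on a few compounds, and the source may have more. Where it says the series, first, only, none or still open, it means among the compounds named here.

Of the compounds shown here, three sharing one core have been tested in a functional assay on PC-3 cells (Homo sapiens) for cytotoxicity, read by MTT assay, with a stated time of 72 h; a higher number here means a weaker inhibitor, a lower number a stronger inhibitor. Compound 1 `COc1ccc(Nc2nc3ccccc3nc2S(=O)(=O)c2ccc(OC)cc2)cc1` gives 8710 nM, compound 2 `COc1ccc(S(=O)(=O)c2nc3ccccc3nc2Nc2ccc(Cl)cc2)cc1` gives 31800 nM, and compound 3 `COc1ccc(S(=O)(=O)c2nc3ccccc3nc2Nc2ccc(C(F)(F)F)cc2)cc1` gives 330 nM. Compound 3 therefore stands lowest of the three: the change from compound 1 to compound 3, trifluoromethyl in place of methoxy on an aromatic carbon, brought a 26-fold lower number from compound 1 to compound 3 (1.42 log units; beyond the scatter), and the change from compound 2 to compound 3 brought a 96-fold lower number from compound 2 to compound 3 (1.98 log units; beyond the scatter), while the move from compound 1 to compound 2 gave a 3.7-fold higher number from compound 1 to compound 2 (0.56 log units; beyond the scatter).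

Compound 4 `O=S(=O)(c1ccc(Br)cc1)c1nc2ccccc2nc1Nc1ccc(C(F)(F)F)cc1` keeps the trifluoromethyl of compound 3 and differs elsewhere: bromo in place of methoxy on an aromatic carbon. For the measured compounds named here, none of the measured steps touch this part of the molecule; all three concern the other aromatic ring, so no direct guide exists. Because compound 3 stands at 330 nM and the change is small in atom count, the step from compound 3 to compound 4 is expected to be modest, a 1.5-fold higher number from compound 3 to compound 4 (0.18 log units; within the scatter), in either direction. The estimate for compound 4 in this assay is 500 nM, with a range from 150 nM to 2000 nM.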

Compound 4, half-maximal inhibitory concentration: 4150 nM
Compound 4: middle estimate off by 8.3-fold (0.92 log units), on the low side; the measured number lies above the stated range.
By their numbers in this assay, from the lowest: compound 3; then compound 4; then compound 1; then compound 2.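

In this assay, for the compounds shown here, the swap from 4-methoxyphenyl to 4-bromophenyl gives a 13-fold higher number from compound 3 to compound 4 (1.10 log units; beyond the scatter), so the second aromatic ring, which none of the earlier steps touched, clearly matters. A single replacement on an aromatic carbon, para to a large group, is enough to produce a large step here, so a change of few atoms at this position cannot be assumed to be a minor one. No available evidence explains why the number rises.

This single pair cannot show whether methoxy favours the lower number or bromo opposes it, and a plain hydrogen, an amine or a carboxylic acid at this position could help separate the two. It also leaves open whether the step would keep its size with chloro or methoxy, rather than trifluoromethyl, on the other ring.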